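The source may report more compounds than this note shows. Statements on the series, on what has been measured and on what is new or still open speak of the compounds shown alone.

Measured so far in a functional assay on BGC-823 cells (Homo sapiens) for antiproliferative activity, read by MTT assay, with a stated time of 48 h; a higher number here means a weaker inhibitor, a lower number a stronger inhibitor 
- compound 1 `c1ccc(CSc2nnc(-c3cnccn3)s2)cc1` gives 21200 nM 
- compound 2 `Brc1cccc(CSc2nnc(-c3cnccn3)n2-c2ccccc2)c1` gives 18300 nM 

Compound 2 has the lowest number of the two, but with 18300 nM in this assay it stands within the usual scatter of compound 1, so the pair cannot be separated on these data. Among the compounds with values here, no two measured compounds differ in one place only, which leaves no direct measure of a change at this position.

The next compound is compound 3 `Fc1cccc(F)c1CSc1nnc(-c2cnccn2)n1-c1ccccc1` and it departs from compound 2 at one place. It has 2,6-difluorophenyl in place of 3-bromophenyl on a saturated chain carbon bound to a sulfur while the rest of the structure stays the same.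

Within the data shown here, with only two values to go on, both of similar size, no step beyond the scatter is expected in this assay and no direction is favoured. The expected step of a 1.0-fold higher number from compound 2 to compound 3 (0.02 log units; within the scatter) is therefore small, with a wide margin for the lack of direct evidence. For compound 3 the estimated value is 19000 nM with an expected range from 8000 nM to 45000 nM in this assay.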

Compound 3, half-maximal inhibitory concentration: > 50000 nM
Compound 3: no number, only a limit (the forecaster's own chance of this, stated with the estimate: 8%); at least 2.6-fold (0.42 log units) between middle value and limit.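

In this assay, replacing 3-bromophenyl with 2,6-difluorophenyl on a saturated chain carbon bound to a sulfur gives an at least 2.7-fold higher number from compound 2 to compound 3 (0.43 log units; beyond the scatter). Within the data shown here, this is the first direct measure of a change at this position, and it shows that the position is not indifferent to the group it carries: the change from 3-bromobenzyl to 2,6-difluorobenzyl costs activity beyond the scatter, with the rest of the structure held constant. The entry for compound 3 is a limit and not a number, so the step gives only a minimum size and the true size remains unknown: the limit of > 50000 nM in this assay, at which 1 of the 3 values shown sits.

This single change alters the halogen, the number of halogens and their places on the ring all at once, so the data cannot assign the loss to any one of these, and no cause can be given. On these data alone, a chlorophenyl or monofluorophenyl group at this position, or a longer chain between the sulfur and the ring, would help separate these factors, and whether any such group gives a lower number than compound 2 remains open.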